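The source may report more compounds than this note shows. Statements on the series, on what has been measured and on what is new or still open speak of the compounds shown alone.

Compound 1 `O=C(Nc1ccc(I)cc1)c1cncc(N2CC3CC(C2)N3)c1` and compound 2 `O=C(c1cncc(N2CC3CC(C2)N3)c1)N1CCCc2ccccc21` share the same core and differ only in the group carried on the carbonyl. In an assay on membranes from Cerebral cortex for displacement of a labelled ligand from Neuronal acetylcholine receptor; alpha4/beta2 (Rattus norvegicus) (a lower number here means a stronger inhibitor, a higher number a weaker inhibitor), compound 1 gives 0.366 nM, and compound 2 gives 0.196 nM. Compound 1 thus has the higher of the two numbers, but its gap to compound 2 lies within the scatter, so the two cannot be told apart on these data. Compound 3 `O=C(Nc1ccc(F)cc1F)c1cncc(N2CC3CC(C2)N3)c1` differs from compound 1 in one place: 2,4-difluorophenyl in place of 4-iodophenyl on an amide-type nitrogen. Within the data shown here, no measured pair shows how this assay responds to an exchange of this kind, so the expectation rests on compound 1 alone. A modest step upward, toward a weaker inhibitor, is expected, one that may only just exceed the scatter. The expected step is a 2.7-fold higher number from compound 1 to compound 3 (0.44 log units; beyond the scatter). Compound 3 is therefore estimated at 1 nM, with a likely range from 0.25 nM to 4.5 nM.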

Compound 3, inhibition constant: 0.051 nM
Estimate against measurement, compound 3: 20-fold (1.29 log units) above; measured number below the stated range.
By their numbers in this assay, from the lowest: compound 3; then compounds 2 and 1 (each within the scatter of the next).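

In this assay, among these compounds, the exchange of 4-iodophenyl for 2,4-difluorophenyl on the amide-type nitrogen gives a 7.2-fold lower number from compound 1 to compound 3 (0.86 log units; beyond the scatter) and so provides the first step at this place that lies beyond the scatter. The number therefore still responds to the aryl group here, even though both groups consist of one six-membered aromatic ring of carbon only and neither carries a hydrogen-bond donor or acceptor. Nothing measured here explains the direction or the size of this step.

The single exchange removes iodine and introduces two fluorines together, so the compounds shown do not separate the contribution of either change. As far as these compounds go, it also remains open how the number would respond to 4-fluorophenyl, or to a phenyl ring carrying an amine or a carboxylic acid, on this nitrogen.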